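A few compounds are considered here, and "the series" means these few. Any claim that something is new, unique, unknown or untested is made for them only; others in the source may bear on it.

Measured so far in a functional assay on A549 cells (Homo sapiens) for cytotoxicity, read by MTT assay, with a stated time of 24 h, tested at 80 uM; on this read-out higher numbers stand for a weaker effect at the one concentration tested and lower numbers for a stronger effect:
- compound 1 `CCCOC(=O)CCC(=O)N1CCN(CCCOc2cc3c(Nc4ccc(F)c(Cl)c4)ncnc3cc2OC)CC1`: 23.4%
- compound 2 `CCCCOC(=O)CCC(=O)N1CCN(CCCOc2cc3c(Nc4ccc(F)c(Cl)c4)ncnc3cc2OC)CC1`: 36.9%
- compound 3 `CCCCCCCCCCCOC(=O)CCC(=O)N1CCN(CCCOc2cc3c(Nc4ccc(F)c(Cl)c4)ncnc3cc2OC)CC1`: 2.8%

Compound 3 stands lowest of the three numbers, that is, it shows the strongest effect at the single concentration; its nearest neighbour is compound 1 and its furthest is compound 2, and both gaps lie beyond the scatter.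

Compound 4 `CCCCCCCCCCCCCCOC(=O)CCC(=O)N1CCN(CCCOc2cc3c(Nc4ccc(F)c(Cl)c4)ncnc3cc2OC)CC1` differs from compound 3 only at the end of the ester chain: propyl in place of hydrogen on a saturated chain carbon, ten or more bonds along the chain from an oxygen next to a carbonyl group.

Going by the values given here, three measured steps bear on chain lengthening at this position. The short extension gave a number 13.5 percentage points higher from compound 1 to compound 2 (beyond the scatter), whereas the long extensions gave a number 20.6 percentage points lower from compound 1 to compound 3 (beyond the scatter) and a number 34.1 percentage points lower from compound 2 to compound 3 (beyond the scatter). Among the compounds with values here, no step is of exactly the same kind as the one to compound 4, and a further extension beyond compound 3 is untested. Compound 3 already sits close to the bottom of the read-out, so any further lowering in this assay is bounded; the expectation is a step within the scatter, at most a slight lowering, which is what a number 0.3 percentage points lower from compound 3 to compound 4 (within the scatter) means here.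

Compound 4 is therefore expected to give about 2.5% in this assay, estimated between 0% and 14%.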

Compound 4, a percentage reported as activity, at one concentration (the size of the read-out at that concentration, not a potency): 77.2%
Compound 4: middle estimate off by 74.7 percentage points, on the low side; the whole stated range lies below it.
By their numbers in this assay, from the lowest: compound 3; then compound 1; then compound 2; then compound 4.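

In this assay, propyl at the far end of the ester chain does not continue the lowering seen up to compound 3: the change gives a number 74.4 percentage points higher from compound 3 to compound 4 (beyond the scatter) and shows that a small addition at this place can carry a large step. The longest ester also separates from both short esters, with a number 40.3 percentage points higher from compound 2 to compound 4 (beyond the scatter) and a number 53.8 percentage points higher from compound 1 to compound 4 (beyond the scatter) on the same read-out, so across the four compounds the number rises, falls and rises again as the chain lengthens, and no single direction holds for this position. No measured evidence is at hand that accounts for this reversal.

From the compounds shown here alone, whether the climb after compound 3 is abrupt or gradual remains open, since methyl or ethyl in place of hydrogen at the end of the chain of compound 3 would fall inside that step. Also open, going by these compounds, is how a carboxylic acid or an amine at the end of a chain of this length would read, and whether a still longer chain would keep the number high.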